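This account rests on a few compounds, and the source may have more. Where it says the series, first, only, none or still open, it means among the compounds named here.

Measured so far in an assay on isolated protein for binding affinity to 5-hydroxytryptamine receptor 3A (Homo sapiens); on this read-out lower numbers stand for stronger inhibition and higher numbers for weaker inhibition:

- compound 1, `c1ccc(-c2n[nH]cc2N2CCNCC2)cc1`, gives > 10000 nM.
- compound 2, `Clc1cccc(-c2n[nH]cc2N2CCNCC2)c1`, gives 806 nM.

The value of compound 1 in this assay is a limit of the assay rather than a number, as given by the limit of > 10000 nM in this assay, at which 1 of the 2 values shown sits. Going by the values given here, compound 2 therefore holds the only actual number in this assay; the one other value shown is a limit. Among the compounds with values here, the single measured step, an at least 12-fold lower number from compound 1 to compound 2 (1.09 log units; beyond the scatter), shows that the chloro group on the aromatic carbon carries a large part of the measured binding.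

Compound 3, `Fc1cccc(-c2n[nH]cc2N2CCNCC2)c1`, has not yet been measured in this assay. It differs from compound 2 by fluoro in place of chloro on an aromatic carbon. Within the data shown here, no measured step compares fluoro with chloro directly; the one step available only shows how much the chloro group adds over hydrogen. The expectation for compound 3 is that part of that gain is lost, a step toward a higher number of about a 3.1-fold higher number from compound 2 to compound 3 (0.49 log units; beyond the scatter). The estimate for compound 3 in this assay is 2500 nM, with a range from 800 nM to 8000 nM.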

Compound 3, inhibition constant: > 10000 nM
Compound 3: only a limit was reported; the forecaster's own chance of this, stated with the estimate: 15%; middle value at least 4.0-fold (0.60 log units) from the limit.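

In this assay, the change from chloro to fluoro on this aromatic carbon gives an at least 12-fold higher number from compound 2 to compound 3 (1.09 log units; beyond the scatter), so the gain seen with chloro in compound 2 does not carry over to fluoro. Among the compounds shown, a measurable number at this place is held by chloro alone. Compound 1 and compound 3 both sit at a limit, so the step between them cannot be read and hydrogen and fluoro cannot be ordered: the limit of > 10000 nM in this assay, at which 2 of the 3 values shown sit.

As far as these compounds go, whether bromo, methyl or trifluoromethyl at this place would give a measurable number, and how it would compare with compound 2, stays open. Also open, from the compounds shown here alone, is whether chloro on another carbon of the six-membered aromatic ring would keep the binding seen with compound 2.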